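Methyl Added to a Compound at the Assay Limit

This account rests on a few compounds, and the source may have more. Where it says the series, first, only, none or still open, it means among the compounds named here.

In an ADME assay on CHO cells (Cricetulus griseus) for inhibition, read by MTT assay (on this read-out lower numbers stand for stronger inhibition and higher numbers for weaker inhibition), compound 1 `CCN(CC)Cc1cccc(Nc2nc3ccccc3n2Cc2ccc(F)cc2)c1O` gives > 50000 nM, which is a limit of the assay and not a number. Compound 2 `CCN(CC)Cc1cccc(Nc2nc3ccccc3n2Cc2ccc(C(F)(F)F)cc2)c1O` gives > 50000 nM, and this too is a limit. For the measured compounds named here, compound 1 therefore has no readable position, and the only other value beside it offers no number for comparison. The evidence amounts to the limit of > 50000 nM in this assay, at which 2 of the 2 values shown sit.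

Compound 3 `CCN(CC)Cc1ccc(C)c(Nc2nc3ccccc3n2Cc2ccc(F)cc2)c1O` carries methyl in place of hydrogen on an aromatic carbon, ortho to a large group, meta to a hydroxy group and para to a (diethylamino)methyl group: methyl in place of hydrogen on an aromatic carbon.

Going by the values given here, the one measured step nearby is a step that the two limits leave unreadable from compound 1 to compound 2, with trifluoromethyl in place of fluoro on an aromatic carbon. It involves a different change and gives no size to carry over. No step beyond the scatter is therefore expected in this assay, in either direction, and another limit is the likeliest report. The expected step is a number no higher from compound 1 to compound 3 (the limit leaves the size open). For compound 3 the estimated value is 50000 nM, with an expected range from 25000 nM to 100000 nM.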

Compound 3, half-maximal inhibitory concentration: > 50000 nM
Compound 3: no number, only a limit; the forecaster's own chance of this, stated with the estimate: 75%; the middle value sits exactly at the limit.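

In this assay compound 3 gives > 50000 nM, which is a limit of the assay and not a number. For the compounds shown here, with compound 1 also at a limit, no step from compound 1 to compound 3 can be read, and the evidence is only this: the limit of > 50000 nM in this assay, at which 3 of the 3 values shown sit. The compounds shown leave open what their actual values are, and whether methyl in place of hydrogen on an aromatic carbon changes the read-out at all.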